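Swapping Nitro for Carboxy on a Shared Core

The compounds below may be only part of what the source reports. "The series", "measured", "known", "first", "only" and "open" are said of these compounds alone.

Three compounds share one core and differ only in the group on the outer aromatic ring. Compound 1 `CC1CC/C(=N\Nc2ccc(Br)cc2)c2ncc(C(=O)O)c(=O)n21` carries a bromo, and in a functional assay on the whole organism for inhibition, with Rattus norvegicus as the target (a lower number here means that less compound is needed, a higher number that more compound is needed for the effect), compound 1 gives 0.8 umol/kg. Compound 2 `COc1ccc(N/N=C2\CCC(C)n3c2ncc(C(=O)O)c3=O)cc1` carries a methoxy, and in this assay compound 2 gives 0.8 umol/kg. Compound 3 `CC1CC/C(=N\Nc2ccc([N+](=O)[O-])cc2)c2ncc(C(=O)O)c(=O)n21` carries a nitro, and in this assay compound 3 gives 0.8 umol/kg, level with both of the others. The steps of no change at the digits printed from compound 1 to compound 2 (within the scatter), no change at the digits printed from compound 1 to compound 3 (within the scatter) and no change at the digits printed from compound 2 to compound 3 (within the scatter) all stayed within the scatter. Compound 4 `CC1CC/C(=N\Nc2ccc(C(=O)O)cc2)c2ncc(C(=O)O)c(=O)n21` takes the step (carboxy in place of nitro on an aromatic carbon). Because no change at the digits printed from compound 1 to compound 3 (within the scatter) and no change at the digits printed from compound 2 to compound 3 (within the scatter) stayed within the scatter, a fourth group at this place is expected to behave alike, so the step of no change at the digits printed from compound 3 to compound 4 (within the scatter) is estimated to stay within the scatter. Compound 4 is therefore expected at 0.8 umol/kg, with a range from 0.4 umol/kg to 1.6 umol/kg.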

Compound 4, dose for 50% inhibition: 7.6 umol/kg
The estimate for compound 4 lay 9.5-fold (0.98 log units) below the measured number, and the stated range ends below it.
By their numbers in this assay, from the lowest: compounds 1, 2 and 3 (each within the scatter of the next); then compound 4.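

In this assay this position proves not to accept every group: carboxy in place of nitro gives a 9.5-fold higher number from compound 3 to compound 4 (0.98 log units; beyond the scatter), carboxy in place of methoxy gives a 9.5-fold higher number from compound 2 to compound 4 (0.98 log units; beyond the scatter), and carboxy in place of bromo gives a 9.5-fold higher number from compound 1 to compound 4 (0.98 log units; beyond the scatter). The level results for bromo, methoxy and nitro therefore do not extend to every group on this aromatic carbon. Nothing measured here bears on why the carboxy step is this large. As far as these compounds go, whether a methyl ester or an amide at this place would stay level with compound 3 or move towards compound 4 remains open.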